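The source may hold more compounds than are shown below. What is called first, only, known or untested is meant among the compounds shown, and "the series" means these compounds.

Working notes on the series. In a functional assay on A549 cells (Homo sapiens) for antiproliferative activity, read by CCK-8 assay, with a stated time of 72 h (on this read-out lower numbers stand for stronger inhibition of growth and higher numbers for weaker inhibition of growth), compound 1 `CCC1C(=O)N(C)c2cnc(-n3ccc4cc(F)ccc43)nc2N1c1ccn(C)n1` is reported as "not active" (no number reported) without a number, so it offers no value to step from. In this assay, for the measured compounds named here, compound 2 `CC[C@@H]1C(=O)N(C)c2cnc(-n3ccc4cc(C(=O)NC)ccc43)nc2N1C1CCCC1` reads 2200 nM as the only number so far. Compound 3 `CCC1C(=O)N(C)c2cnc(-n3ccc4cc(C(=O)NC5CCCC5)ccc43)nc2N1c1ccn(C)n1` departs from compound 1 by cyclopentylcarbamoyl in place of fluoro on an aromatic carbon with cyclopentylcarbamoyl in place of fluoro on an aromatic carbon. No measured pair sizes this step in this assay so only a direction is expected: stronger inhibition of growth than compound 1 shows, by an unknown amount. Compound 3 is expected near 3000 nM with an estimated range from 500 nM to 18000 nM for its first measurement.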

Compound 3, concentration for 50% growth inhibition: 39500 nM
The estimate for compound 3 lay 13-fold (1.12 log units) below the measured number; the whole stated range lies below it.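

For the compounds shown here, compound 1 has no number in this assay, so no step to compound 3 can be read. From the compounds shown here alone, how cyclopentylcarbamoyl in place of fluoro shifts growth inhibition stays open. No supporting evidence bears on this result.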